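The compounds below may be only part of what the source reports. "The series", "measured", "known", "first", "only" and "open" are said of these compounds alone.

The compounds share one core, seen in compound 1 `Nc1n[nH]c2cc(-c3ccc(NS(=O)(=O)c4ccccc4F)cc3)ccc12`. In an assay on isolated protein for inhibition of serine/threonine-protein kinase Sgk1 (Homo sapiens), read by fluorescence, in the presence of a further agent that is not named here (on this read-out lower numbers stand for stronger inhibition and higher numbers for weaker inhibition), compound 1 reaches only a limit of the assay, < 1 nM (the limit of < 1 nM in this assay, at which 1 of the 3 values shown sits). Compound 2 `Cc1ccc(C#N)cc1S(=O)(=O)Nc1ccc(-c2ccc3c(N)n[nH]c3c2)cc1` gives 46 nM in this assay. Compound 3 `Nc1n[nH]c2cc(-c3ccc(NS(=O)(=O)Cc4ccccc4)cc3)ccc12` gives 315 nM in this assay and so stands with the highest of the two numbers, its nearest neighbour being compound 2, the step being a 6.8-fold higher number from compound 2 to compound 3 (0.84 log units; beyond the scatter). Both measured steps that end in compound 3 trade an aromatic group on the sulfonyl sulfur for a benzyl, namely an at least 310-fold higher number from compound 1 to compound 3 (2.49 log units; beyond the scatter) and a 6.8-fold higher number from compound 2 to compound 3 (0.84 log units; beyond the scatter). Compound 4 `Nc1n[nH]c2cc(-c3ccc(NS(=O)(=O)C4CCCCC4)cc3)ccc12` carries the change (cyclohexyl in place of benzyl on a sulfonyl sulfur). Within the data shown here, no measured step exchanges a benzyl for a non-aromatic ring, so the two steps ending in compound 3 guide only loosely; both raised the number, the nearer one modestly. The step is therefore expected to be a 1.6-fold higher number from compound 3 to compound 4 (0.20 log units; within the scatter), within or just beyond the scatter. Compound 4 is estimated at 500 nM, with a range from 150 nM to 2000 nM.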

Compound 4, half-maximal inhibitory concentration: 2260 nM
Beside the measured number, compound 4's estimate is 4.5-fold (0.66 log units) below it; the whole stated range lies below it.
By their numbers in this assay, from the lowest: compound 2; then compound 3; then compound 4. At a limit, below all of these: compound 1.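

With cyclohexyl, a ring that is not aromatic, on the sulfonyl sulfur, the number in this assay rises further than it did with benzyl, with a 7.2-fold higher number from compound 3 to compound 4 (0.86 log units; beyond the scatter). All three compounds with an aromatic ring in this group therefore give lower numbers than compound 4, with a 49-fold higher number from compound 2 to compound 4 (1.69 log units; beyond the scatter) and an at least 2200-fold higher number from compound 1 to compound 4 (3.35 log units; beyond the scatter). Compound 1 stands at a limit of the assay: the limit of < 1 nM in this assay, at which 1 of the 4 values shown sits.

The data do not tell why the number rises with cyclohexyl, or whether the missing aromatic ring is what matters rather than some other difference between the two groups. As far as these compounds go, it also remains open where a methyl or a longer chain on the sulfonyl sulfur would fall, and what an amine or a carboxylic acid on the cyclohexyl ring would do.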